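Adding a Cyanomethyl Group: Same Change on a Second Core

This account rests on a few compounds, and the source may have more. Where it says the series, first, only, none or still open, it means among the compounds named here.

Compound 1 `CO[C@]1(c2cc(F)cc(Sc3ccc(/C(C)=N/O)cc3)c2)CCO[C@@H](C)C1` and compound 3 `CO[C@]1(c2cc(F)cc(Sc3ccc(/C(C)=N/OCC#N)cc3)c2)CCO[C@@H](C)C1` differ in one place only: cyanomethyl in place of hydrogen on an oxygen. In a functional assay (blood) for inhibition, with Homo sapiens as the target (on this read-out lower numbers stand for stronger inhibition and higher numbers for weaker inhibition), compound 1 gives 40 nM, and compound 3 gives 40 nM; the step of no change at the digits printed from compound 1 to compound 3 (within the scatter) stays within the usual scatter. Compound 2 `COC1(c2cc(F)cc(Sc3ccc4c(c3)CC/C4=N\O)c2)CCOCC1` is built on a different core, and the difference between the two cores is not broken down here. In this assay compound 2 gives 290 nM, which is weaker inhibition than compound 1 and compound 3 show, beyond the scatter in both cases. Compound 4 `COC1(c2cc(F)cc(Sc3ccc4c(c3)CC/C4=N\OCC#N)c2)CCOCC1` carries the same change applied to the core of compound 2: cyanomethyl in place of hydrogen on an oxygen. The place of the change is described identically in both pairs. Because no change at the digits printed from compound 1 to compound 3 (within the scatter) showed no movement on the first core, compound 4 is expected to stay close to compound 2, with an expected step of no change at the digits printed from compound 2 to compound 4 (within the scatter). For compound 4 the estimated value in this assay is 290 nM, likely lying between 110 nM and 800 nM.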

Compound 4, half-maximal inhibitory concentration: 30 nM
Compound 4: middle estimate off by 9.7-fold (0.99 log units), on the high side; the measured number lies below the stated range.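

Putting cyanomethyl in place of hydrogen on the oxygen gives, in this assay, a 9.7-fold lower number from compound 2 to compound 4 (0.99 log units; beyond the scatter), so the same change did not give the same result on the two cores: the same change on two cores in this assay, no change at the digits printed (within the scatter) from compound 1 to compound 3 and a 9.7-fold lower number (0.99 log units; beyond the scatter) from compound 2 to compound 4, 9.7-fold (0.99 log units) apart, beyond the scatter of two such steps

In this series, then, the result of this change on one core was a poor guide to its result on the other. These two pairs do not show why the steps differ, which part of the cores matters, or how the change would behave on any further core.

The compounds shown leave open what a plain methyl group, a longer chain ending in a nitrile, or a carboxylic acid on that oxygen would do. They also leave open whether such groups would give different steps on the two cores.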